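The compounds below may be only part of what the source reports. "The series", "measured", "known", "first", "only" and "open" are said of these compounds alone.

Working notes on the series, read in an ADME assay on the whole organism (strain FVB) for pharmacokinetics, with Mus musculus as the target, read by LC-MS, at a dose of 30 mg/kg by the oral route; on this read-out higher numbers stand for higher exposure at the dose given and lower numbers for lower exposure. For the measured compounds named here, compound 1 (`NCCOc1ccc([C@H]2CC[C@]3(CC2)OOC2(O3)C3CC4CC(C3)CC2C4)cc1`) gives 287 nM, the lower of the two numbers so far. Compound 2 (`CC(C)(O)CN1CCC(Oc2ccc([C@H]3CC[C@]4(CC3)OOC3(O4)C4CC5CC(C4)CC3C5)cc2)CC1`) gives 1810 nM.

Compound 3 (`CC(C)(N)CCOc1ccc([C@H]2CC[C@]3(CC2)OOC2(O3)C3CC4CC(C3)CC2C4)cc1`) keeps the core of compound 1 and carries this change: 1-amino-1-methylethyl in place of amino on a saturated chain carbon, two bonds along the chain from an oxygen on an aromatic ring. Cut one bond further out, this reads as 3-amino-3-methylbutyl in place of 2-aminoethyl.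

Going by the values given here, only one measured step bears on this change, and it is beyond the scatter: a 6.3-fold higher number from compound 1 to compound 2 (0.80 log units; beyond the scatter). That step also alters the group on the oxygen on the aromatic ring, but what enters there is a different and larger group, so it is a loose guide. Among the compounds with values here, no measured compound yet shows the effect of the 3-amino-3-methylbutyl group itself.

Within the data shown here, on this single precedent, a rise smaller than the one seen with compound 2 is expected in this assay, and a step within the scatter cannot be excluded. The estimated step is a 2.3-fold higher number from compound 1 to compound 3 (0.36 log units; beyond the scatter). Compound 3 is expected at 650 nM, with an estimated range of 200 nM to 2200 nM.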

Compound 3, maximal plasma concentration: 1050 nM
For compound 3 the middle estimate is 1.6-fold (0.21 log units) below the measured one; the measured number falls inside the stated range.
By their numbers in this assay, from the lowest: compound 1; then compounds 3 and 2 (each within the scatter of the next).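

In this assay, the 3-amino-3-methylbutyl group now gives a direct reading on the oxygen on the aromatic ring, with a 3.7-fold higher number from compound 1 to compound 3 (0.56 log units; beyond the scatter), so a rise beyond the scatter at this position does not require the 1-(2-hydroxy-2-methylpropyl)piperidin-4-yl group. Against that larger group, the reading is a 1.7-fold lower number from compound 2 to compound 3 (0.24 log units; within the scatter), which leaves compound 2 and compound 3 indistinguishable on this read-out, although the group that enters in compound 3 has no ring and keeps an amino group on the chain. No supporting measurement is available that could account for either step.

The compounds shown leave open whether the step from compound 1 to compound 3 follows from the longer chain or from the methyl branching, a question that an unbranched 3-aminopropyl group and a 2-amino-2-methylpropyl group on the same oxygen could help to separate. Also open, going by these compounds, is whether the amino group itself is needed for this exposure, which a hydroxyl group or a carboxylic acid in its place on the 3-methylbutyl chain would test.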